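The source may report more compounds than this note shows. Statements on the series, on what has been measured and on what is new or still open speak of the compounds shown alone.

Working notes on the arylidene hydrazide series.

Of the compounds shown here, three carry numbers so far. Compound 1 `Cn1nnnc1SCC(=O)N/N=C/c1ccccc1` is the unsubstituted parent; in a functional assay on A549 cells (Homo sapiens) for cytotoxicity, read by XTT assay, with a stated time of 24 h (a higher number here means a weaker inhibitor, a lower number a stronger inhibitor), compound 1 gives 3160000 nM. Compound 2 `Cn1nnnc1SCC(=O)N/N=C/c1ccc([N+](=O)[O-])cc1` carries a nitro on the aromatic carbon, and in this assay compound 2 gives 632000 nM. Compound 3 `CN(C)c1ccc(/C=N/NC(=O)CSc2nnnn2C)cc1` carries a dimethylamino at that carbon, and in this assay compound 3 gives 100000 nM. Compound 2 therefore stands second highest of the three: the step of a 5.0-fold lower number from compound 1 to compound 2 (0.70 log units; beyond the scatter) is modest, the step of a 6.3-fold lower number from compound 2 to compound 3 (0.80 log units; beyond the scatter) is modest, and the step of a 32-fold lower number from compound 1 to compound 3 (1.50 log units; beyond the scatter) is large.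

The next compound, compound 4 `Cn1nnnc1SCC(=O)N/N=C/c1ccc(O)cc1`, differs from compound 2 by hydroxy in place of nitro on an aromatic carbon.

Among the measured compounds shown here, the steps that bear on this change are the two that start or end at compound 2. Removing the nitro altogether returns to compound 1, which is a move upward by the size of a 5.0-fold lower number from compound 1 to compound 2 (0.70 log units; beyond the scatter); replacing nitro by a group of the dimethylamino kind moves downward by a 6.3-fold lower number from compound 2 to compound 3 (0.80 log units; beyond the scatter). For the measured compounds named here, a hydroxy is neither of these, and no measured step has a hydroxy in it. The expectation for compound 4 in this assay is therefore a number close to that of compound 2, within about a step of the size of a 1.6-fold higher number from compound 2 to compound 4 (0.20 log units; within the scatter) upward, with a wide range. Compound 4 is estimated at 1000000 nM, between 300000 nM and 3200000 nM.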

Compound 4, half-maximal inhibitory concentration: > 10000000 nM
Compound 4: only a limit was reported; the forecaster's own chance of this, stated with the estimate: 10%; middle value at least 10-fold (1.00 log units) away from the limit.
By their numbers in this assay, from the lowest: compound 3; then compound 2; then compound 1. At a limit, above all of these: compound 4.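

In this assay compound 4 gives only a limit, the one such result in the series: the limit of > 10000000 nM in this assay, at which 1 of the 4 values shown sits. Until now, both substituents on this aromatic carbon, para to a large group, gave a lower number than hydrogen, but hydroxy goes against that trend, with an at least 3.1-fold higher number from compound 1 to compound 4 (0.50 log units; beyond the scatter), so a substituent at this carbon does not by itself lower the number. Among the compounds shown here, exchanging nitro for hydroxy also moves the number the opposite way from exchanging nitro for dimethylamino, with an at least 15-fold higher number from compound 2 to compound 4 (1.19 log units; beyond the scatter), and the exchange of dimethylamino for hydroxy gives an at least 100-fold higher number from compound 3 to compound 4 (2.00 log units; beyond the scatter), the widest gap of any pair so far.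

Going by these compounds, the actual value of compound 4 remains unknown, so these three steps set only minimum sizes and the full gap between hydroxy and the other groups stays unresolved. A methoxy or a primary amine on the same carbon would show whether the hydroxy result depends on the free hydroxy hydrogen and whether the result for dimethylamino extends to a simpler amine.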